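The source may report more compounds than this note shows. Statements on the series, on what has been measured and on what is new or still open speak of the compounds shown alone.

Series notes in a functional assay on ECa-109 cells (Homo sapiens) for antiproliferative activity, read by MTT assay, with a stated time of 48 h; on this read-out lower numbers stand for stronger inhibition and higher numbers for weaker inhibition. Compound 1 `Cn1cc(C2=C(c3nn(CCn4ccnc4)c4ncccc34)C(=O)NC2=O)c2ccccc21` reaches only the limit of this assay at > 100000 nM. Compound 2 `Cn1cc(C2=C(c3nn(CCCCn4ccnc4)c4ncccc34)C(=O)NC2=O)c2ccccc21` gives 23500 nM, the highest of the two numbers shown. The nearest number belongs to compound 3 `Cn1cc(C2=C(c3nn(CCCCn4ccnc4)c4ncccc34)C(=O)N(c3ccccc3)C2=O)c2ccccc21` at 7540 nM, with a 3.1-fold lower number from compound 2 to compound 3 (0.49 log units; beyond the scatter). The step that bears on the new compound is the linker extension, an at least 4.2-fold lower number from compound 1 to compound 2 (0.62 log units; beyond the scatter). Compound 4 `Cn1cc(C2=C(c3nn(CCCn4ccnc4)c4ncccc34)C(=O)NC2=O)c2ccccc21` differs from compound 2 in that (1H-imidazol-1-yl in place of (1H-imidazol-1-yl)methyl on a saturated chain carbon, three bonds along the chain from an aromatic nitrogen). The linker is thereby shortened back toward that of compound 1, though not as far. A modest rise in this assay is therefore expected for compound 4, a 2.1-fold higher number from compound 2 to compound 4 (0.33 log units; beyond the scatter). The expected size is below the full gap between compound 1 and compound 2. Compound 4 is estimated at 50000 nM, in the range 18000 nM to 140000 nM.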

Compound 4, half-maximal inhibitory concentration: > 100000 nM
Compound 4: only a limit was reported (the forecaster's own chance of this, stated with the estimate: 25%); middle value at least 2.0-fold (0.30 log units) from the limit.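

In this assay, among these compounds, the single change from 4-(1H-imidazol-1-yl)butyl to 3-(1H-imidazol-1-yl)propyl gives an at least 4.2-fold higher number from compound 2 to compound 4 (0.62 log units; beyond the scatter) and shows that the readable number of compound 2 depends on the full butyl chain. Compound 4 gives > 100000 nM as a limit, not a number. The step between compound 1 and compound 4 cannot be read because both stand at a limit: the limit of > 100000 nM in this assay, at which 2 of the 4 values shown sit.

Open, on these data alone, is whether a longer chain, such as pentyl, lowers the number further. Also open, as far as these compounds go, is whether an amine can replace the imidazole at the chain end.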